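Compound 4: a smaller group on the carbonyl carbon

The compounds below may be only part of what the source reports. "The series", "measured", "known", "first", "only" and "open" are said of these compounds alone.

Measured so far, in a functional assay on Caco-2 cells (Homo sapiens) for antiproliferative activity, read by MTT assay, with a stated time of 48 h; a lower number here means a stronger inhibitor, a higher number a weaker inhibitor:
compound 1 `CCn1c(C(=O)N(CCC#N)CCC#N)ccc1C(CC)(CC)c1ccc(OCCC(O)(CC)CC)c(C)c1` gives > 50000 nM, a limit of the assay.
compound 2 `C#CC(C)OC(=O)c1ccc(C(CC)(CC)c2ccc(OCCC(O)(CC)CC)c(C)c2)n1CC` gives > 50000 nM, also a limit of the assay.
compound 3 `CCn1c(C(=O)NC(C)C(=O)O)ccc1C(CC)(CC)c1ccc(OCCC(O)(CC)CC)c(C)c1` gives 46500 nM.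

Compound 1 thus stands only at a limit in this assay, not at a number, and (the limit of > 50000 nM in this assay, at which 2 of the 3 values shown sit). Going by the values given here, the one value that is a number, that of compound 3, sits close to that limit.

Compound 4 `CCn1c(C(=O)N(C)CCO)ccc1C(CC)(CC)c1ccc(OCCC(O)(CC)CC)c(C)c1` differs from compound 1 in one place: a group of 5 heavy atoms (3 carbon, 1 nitrogen, 1 oxygen; no ring) in place of a group of 9 heavy atoms (6 carbon, 3 nitrogen; no ring), on a carbonyl carbon. Two measured steps exchange the same group on the same carbonyl carbon of compound 1. One is a step that the two limits leave unreadable from compound 1 to compound 2. The other is an at least 1.0-fold lower number from compound 1 to compound 3 (0.03 log units; that floor lies within the scatter). Neither shows a change beyond the scatter, and the (2-hydroxyethyl)(methyl)amino group entering in compound 4 is a third variant at that position. The expected step is accordingly a step that the limit leaves unreadable from compound 1 to compound 4, with a limit the most likely outcome. Compound 4 is expected to give 60000 nM, within a range from 30000 nM to 150000 nM.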

Compound 4, half-maximal inhibitory concentration: 74 nM
Compound 4: the middle estimate sits 810-fold (2.91 log units) above what was measured, outside the stated range (below it).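

In this assay, going by these compounds alone, the group on the carbonyl carbon proves able to move the read-out far on an unchanged core, which no earlier step showed: (2-hydroxyethyl)(methyl)amino brings an at least 670-fold lower number from compound 1 to compound 4 (2.82 log units; beyond the scatter), an at least 670-fold lower number from compound 2 to compound 4 (2.82 log units; beyond the scatter) and a 630-fold lower number from compound 3 to compound 4 (2.80 log units; beyond the scatter). The steps that start from compound 1 and compound 2 give only floors, not sizes: the limit of > 50000 nM in this assay, at which 2 of the 4 values shown sit.

The compounds shown leave open whether the hydroxyl or the methyl of the entering group matters more. They also leave open how a 2-methoxyethylamino or a dimethylamino group would read at this carbonyl carbon.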